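This account rests on a few compounds, and the source may have more. Where it says the series, first, only, none or still open, it means among the compounds named here.

Measured compounds:
compound 1 `O=[N+]([O-])c1cn2c(n1)[S+]([O-])CC(Oc1ccc(C(F)(F)F)cn1)C2`: > 64000 nM; 30000 nM (2 entries)
compound 2 `O=[N+]([O-])c1cn2c(n1)[S@@+]([O-])C[C@@H](OCc1ccc(OC(F)(F)F)cc1)C2`: > 64000 nM

In an ADME assay on MRC5 cells (Homo sapiens) for cytotoxicity (a lower number here means a stronger inhibitor, a higher number a weaker inhibitor), compound 1 gives > 64000 nM; 30000 nM (2 entries); the repeat entries the several entries of compound 1 in this assay, > 64000 nM; 30000 nM (2 entries) do not settle on a single number. Compound 2 gives only a limit of the assay in this assay, > 64000 nM, with no single number behind it. Compound 2 thus stands at the limit (the limit of > 64000 nM in this assay, at which 1 of the 2 values shown sits), so its true reading is not fixed beyond that bound.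

Compound 3 `O=[N+]([O-])c1cn2c(n1)[S@@+]([O-])C[C@H](OCc1ccc(OC(F)(F)F)cc1)C2` is the next member. Against compound 2 the change is the two compounds have the same atoms and bonds and differ only in configuration as drawn: 1 of 2 stereo elements differ; a stereocentre at a saturated ring carbon is drawn S in compound 2 and R in compound 3. Among the measured compounds shown here, no measured pair in the set shares this kind of change, so no reference step exists for it in this assay.

The expected step of a number no higher from compound 2 to compound 3 (the limit leaves the size open) is none beyond the usual scatter. Compound 3 is expected to read 64000 nM in this assay, within 25000 nM to 160000 nM, most probably again reported as a limit.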

Compound 3, half-maximal inhibitory concentration: > 64000 nM
Compound 3 was reported as a limit; the forecaster's own chance of this, stated with the estimate: 75%; the middle value sits exactly at the limit.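

In this assay compound 2 and compound 3 both stand as limits, not numbers, so no step between them can be read: the limit of > 64000 nM in this assay, at which 2 of the 3 values shown sit.

As far as these compounds go, whether the stereocentre at the saturated ring carbon, drawn S in compound 2 and R in compound 3, shifts the reading at all remains open.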